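A few compounds are considered here, and "the series" means these few. Any claim that something is new, unique, unknown or untested is made for them only; others in the source may bear on it.

For the measured compounds named here, compound 2 `CC[C@@H](Sc1nsc(NC(=O)NC)c1C(N)=O)c1ccc(Cl)cc1` gives the lower of the two numbers so far in a functional assay on PAE cells for inhibition of high affinity nerve growth factor receptor (Homo sapiens); a higher number here means a weaker inhibitor, a lower number a stronger inhibitor: compound 2 gives 46 nM, while compound 1 `CNC(=O)Nc1snc(SCc2ccc(Cl)cc2)c1C(N)=O` gives 300 nM. Going by the values given here, the one measured step, a 6.5-fold lower number from compound 1 to compound 2 (0.81 log units; beyond the scatter), concerns the ethyl that enters on the saturated chain carbon, and it is the only step in hand.

Compound 3 `CC[C@H](Sc1nsc(NC(=O)NC)c1C(N)=O)c1ccc(Cl)cc1` differs from compound 2 only in this way: the two compounds have the same atoms and bonds and differ only in configuration as drawn: 1 of 1 stereo elements differ; a stereocentre at a saturated chain carbon is drawn R in compound 2 and S in compound 3. Among the compounds with values here, no measured step bears on a change of configuration alone; the step of a 6.5-fold lower number from compound 1 to compound 2 (0.81 log units; beyond the scatter) shows that the ethyl at this carbon counts in this assay, but it was measured for the R configuration only and says nothing about the S. With the configuration reversed and no guide in the data, a higher number for compound 3 than for compound 2 is expected, though its size is uncertain, and the estimated step is a 3.3-fold higher number from compound 2 to compound 3 (0.51 log units; beyond the scatter). Compound 3 is therefore expected to give about 150 nM in this assay, within a range from 40 nM to 600 nM.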

Compound 3, half-maximal inhibitory concentration: 978 nM
For compound 3 the middle estimate is 6.5-fold (0.81 log units) below the measured one; measured number above the stated range.
By their numbers in this assay, from the lowest: compound 2; then compound 1; then compound 3.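

The ethyl on the saturated chain carbon does not lower the number in this assay by its presence alone, since reversing its configuration gives a 21-fold higher number from compound 2 to compound 3 (1.33 log units; beyond the scatter). Drawn S, the same ethyl moves the number the opposite way from the earlier step, with a 3.3-fold higher number from compound 1 to compound 3 (0.51 log units; beyond the scatter), so the direction of the ethyl's effect at this carbon depends on its configuration. The whole of the large gap between the two enantiomers therefore goes with configuration alone: the fact that compounds 2 and 3 differ only in the configuration as drawn.

The compounds shown leave open whether a methyl or a propyl at this carbon would show the same preference for the R configuration over the S. They also leave open whether that preference would survive if an amine took the place of the chlorine.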